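This account rests on a few compounds, and the source may have more. Where it says the series, first, only, none or still open, it means among the compounds named here.

Measured in a functional assay on HeLa cells (Homo sapiens) for antiproliferative activity, read by MTT assay, with a stated time of 24 h; a higher number here means a weaker inhibitor, a lower number a stronger inhibitor:
- Compound 1 `c1ccc(CSc2nnc(-c3ccc4c(c3)OCCO4)n2-c2ccccc2)cc1`: 32800 nM
- Compound 2 `COc1cccc(CSc2nnc(-c3ccc4c(c3)OCCO4)n2-c2ccccc2)c1`: > 100000 nM, a limit of the assay
- Compound 3 `Brc1ccccc1CSc1nnc(-c2ccc3c(c2)OCCO3)n1-c1ccccc1`: > 100000 nM, a limit of the assay

Compound 3 therefore has no number of its own, only the limit > 100000 nM. It shares that position with one other compound, as the limit of > 100000 nM in this assay, at which 2 of the 3 values shown sit, shows.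

Compound 4 `Brc1ccc(CSc2nnc(-c3ccc4c(c3)OCCO4)n2-c2ccccc2)cc1` has not yet been measured. It differs from compound 3 by 4-bromophenyl in place of 2-bromophenyl on a saturated chain carbon bound to a sulfur, with 4-bromophenyl in place of 2-bromophenyl on a saturated chain carbon bound to a sulfur. The two have the same atoms, joined differently.

Among the compounds with values here, no measured step moves a bromo group in this way, so the evidence is indirect. Bromo in place of hydrogen on an aromatic carbon gave an at least 3.0-fold higher number from compound 1 to compound 3 (0.48 log units; beyond the scatter), and methoxy in place of hydrogen gave an at least 3.0-fold higher number from compound 1 to compound 2 (0.48 log units; beyond the scatter). Both steps are beyond the scatter, but both end at a limit. The remaining comparison is a step that the two limits leave unreadable from compound 2 to compound 3, which gives no size to work from.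

Compound 1, at 32800 nM, is the only measured anchor, so compound 4 is expected to lie near that value or to give a higher number. The expected change is modest, towards a lower number: an at least 1.6-fold lower number from compound 3 to compound 4 (0.22 log units; that floor lies within the scatter). For compound 4 the estimated value is 60000 nM, with an expected range from 20000 nM to 150000 nM.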

Compound 4, half-maximal inhibitory concentration: 54600 nM
For compound 4 the middle estimate is 1.1-fold (0.04 log units) above the measured one; measured number inside the range.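

Compound 4 gives the bromo series its first number of its own in this assay, so the change from 2-bromophenyl to 4-bromophenyl on a saturated chain carbon bound to a sulfur now has a direction, an at least 1.8-fold lower number from compound 3 to compound 4 (0.26 log units; that floor lies within the scatter), though that floor does not yet establish a real effect of the bromo position. The comparison with the methoxy compound has the same limitation, an at least 1.8-fold lower number from compound 2 to compound 4 (0.26 log units; that floor lies within the scatter), and the step between compound 2 and compound 3 still cannot be read: both remain limits rather than numbers, which fixes the position of neither: the limit of > 100000 nM in this assay, at which 2 of the 4 values shown sit. The new result also qualifies the earlier bromo step, since the 2-bromophenyl case gave an at least 3.0-fold higher number from compound 1 to compound 3 (0.48 log units; beyond the scatter), whereas the 4-bromophenyl case gives a 1.7-fold higher number from compound 1 to compound 4 (0.22 log units; within the scatter), so bromo in place of hydrogen does not separate compounds beyond the scatter at both places.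

The compounds shown leave open how far the 2-bromophenyl compound truly lies from the 4-bromophenyl compound in this assay. They also leave open how an amine or a carboxylic acid on the phenyl group, or a longer chain to the sulfur, would read in this assay.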